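The source may hold more compounds than are shown below. What is called first, only, known or untested is meant among the compounds shown, and "the series" means these compounds.

Compound 1, `COc1cc(C)cc(-c2c(-c3ccnc(-c4ccc(C(C)=O)cc4)c3)cnn2CC#N)c1`, gives in a functional assay on HT-29 cells (Homo sapiens) for inhibition, read by sulforhodamine B assay, with a stated time of 48 h (a higher number here means a weaker inhibitor of growth, a lower number a stronger inhibitor of growth), a value of > 100000 nM.
Compound 2, `Cc1cc(O)cc(-c2nn(CC#N)cc2-c2ccnc(-c3ccc(Oc4ccccc4)cc3)c2)c1`, gives in this assay a value of 3840 nM.
Compound 3, `COc1cc(C)cc(-c2nn(CC#N)cc2-c2ccnc(-c3ccc(N(C)C)cc3)c2)c1`, gives in this assay a value of 2880 nM.

Of these three, only compounds 2 and 3 carry numbers. The entry for compound 1 is a limit of the assay, not a number, and it sits at the limit of > 100000 nM in this assay, at which 1 of the 3 values shown sits. Compound 3 has the lowest of the two numbers, but compound 2 stands within the usual scatter of it, so the two cannot be told apart.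

Compound 4, `Cc1cc(O)cc(-c2nn(CC#N)cc2-c2ccnc(-c3ccc(N(C)C)cc3)c2)c1`, has not yet been measured in this assay. It differs from compound 3 in one place: hydrogen in place of methyl on an oxygen on an aromatic ring, that is, methoxy to hydroxy on the 3-methoxy-5-methylphenyl ring, giving 3-hydroxy-5-methylphenyl. Within the data shown here, compound 2 carries this same hydroxy ring, but with a different group on the other aryl, so no single measured step isolates the change.

Given that compound 2 at 3840 nM and compound 3 at 2880 nM fall within the scatter of each other, compound 4 is expected to shift by a 1.0-fold higher number from compound 3 to compound 4 (0.02 log units; within the scatter), which is no step beyond the scatter. Compound 4 is therefore estimated at 3000 nM, with a range from 1000 nM to 9000 nM.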

Compound 4, concentration for total growth inhibition: 20800 nM
Compound 4: the middle estimate sits 6.9-fold (0.84 log units) below what was measured, and the stated range ends below it.
By their numbers in this assay, from the lowest: compounds 3 and 2 (each within the scatter of the next); then compound 4. At a limit, above all of these: compound 1.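

In this assay methoxy on this ring proves not to be interchangeable with hydroxy: the change from 3-methoxy-5-methylphenyl to 3-hydroxy-5-methylphenyl gives a 7.2-fold higher number from compound 3 to compound 4 (0.86 log units; beyond the scatter) when the other aryl carries dimethylamino. With the hydroxy ring held fixed, the other aryl matters as well, since dimethylamino in place of phenoxy gives a 5.4-fold higher number from compound 2 to compound 4 (0.73 log units; beyond the scatter) and so shows a dependence that compound 2 and compound 3, which differ in two places, could not show. Nothing given here accounts for either step.

Going by these compounds, it remains open whether methoxy to hydroxy would give a step of the same size with phenoxy on the other aryl. On these data alone, it is also open how an ethoxy group, an amine or a fluorine on the same ring carbon would compare with methoxy and hydroxy.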